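(2-Phenylethenyl)carbonyl in Place of Benzoyl on Compound 3

The source may hold more compounds than are shown below. What is called first, only, known or untested is meant among the compounds shown, and "the series" means these compounds.

Compound 1 `CCCCCCCCNC(=O)[C@@H](NC(=O)c1ccccc1)[C@@H](C)O`: 136000 nM in a functional assay on HepG2 cells (Homo sapiens) for cytotoxicity, read by MTT assay, with a stated time of 48 h; a higher number here means a weaker inhibitor, a lower number a stronger inhibitor.
Compound 2 `CCCCCCCCCCCCNC(=O)[C@@H](NC(=O)c1ccccc1)[C@@H](C)O`: > 400000 nM, a limit of this assay.
Compound 3 `CCCCCCCCCCCCCCCCCCNC(=O)[C@@H](NC(=O)c1ccccc1)[C@@H](C)O`: > 400000 nM, also a limit of this assay.

Compound 3 thus stands at the limit of this assay, where (the limit of > 400000 nM in this assay, at which 2 of the 3 values shown sit). Along the chain, an at least 2.9-fold higher number from compound 1 to compound 3 (0.46 log units; beyond the scatter), and an at least 2.9-fold higher number from compound 1 to compound 2 (0.46 log units; beyond the scatter) points the same way; a step that the two limits leave unreadable from compound 2 to compound 3. Compound 4 `CCCCCCCCCCCCCCCCCCNC(=O)[C@@H](NC(=O)/C=C/c1ccccc1)[C@@H](C)O` differs from compound 3 by 2-phenylethenyl in place of phenyl on a carbonyl carbon. For the measured compounds named here, none of the measured steps touches this part of the structure, so no size can be read for it from them; what they show is that the chain extension brings compound 3 to the limit. Compound 4 is therefore expected to remain near that limit, a step that the limit leaves unreadable from compound 3 to compound 4. Compound 4 is estimated at 450000 nM, between 150000 nM and 1500000 nM.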

Compound 4, half-maximal inhibitory concentration: 128000 nM
For compound 4 the middle estimate is 3.5-fold (0.55 log units) above the measured one; measured number outside the range, below it.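

The acyl side of the molecule also moves the read-out, which the chain steps alone did not show: in this assay, 2-phenylethenyl in place of phenyl on a carbonyl carbon gives an at least 3.1-fold lower number from compound 3 to compound 4 (0.49 log units; beyond the scatter). The long chain therefore does not by itself hold a compound at the limit. The value of compound 3 is a limit and not a number, so this step has no upper size: the limit of > 400000 nM in this assay, at which 2 of the 4 values shown sit.

The compounds shown leave open whether 2-phenylethenyl would change the read-out on the shorter chain of compound 1. They also leave open whether a saturated 2-phenylethyl group would match it.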